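Extending compound 2 with a tert-butoxycarbonyl group

A few compounds are considered here, and "the series" means these few. Any claim that something is new, unique, unknown or untested is made for them only; others in the source may bear on it.

Three related compounds have been tested so far in a functional assay (strain AB) with Danio rerio as the target, read by microscopy, with a stated time of 1 h; on this read-out higher numbers stand for an effect only at larger amounts of compound and lower numbers for an effect already at smaller amounts. Compound 2 `CN1CCc2c(sc(NC(=O)Nc3ccc(Cl)cc3)c2C(N)=O)C1` gives 4700 nM, and compound 1 `CCN1CCc2c(sc(NC(=S)Nc3ccc(Cl)cc3)c2C(N)=O)C1` gives 6570 nM. These two numbers lie within the usual scatter of repeated measurements, so they cannot be told apart. Compound 3 `CCN1CCc2c(sc(NC(=O)Nc3ccc(Cl)cc3)c2C#N)C1` gives > 25000 nM, which is a limit of the assay and not a number. Among the compounds with values here, compound 2 therefore sits with compound 1 as one of the only two compounds with a measured number.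

The next compound to be tested is compound 4 `CC(C)(C)OC(=O)CCN1CCc2c(sc(NC(=O)Nc3ccc(Cl)cc3)c2C(N)=O)C1`. It differs from compound 2 in one place: (tert-butoxycarbonyl)methyl in place of hydrogen on a saturated chain carbon bound to an amine nitrogen in a ring. The same difference, cut one bond further out, reads methyl to 2-(tert-butoxycarbonyl)ethyl. The rest of the structure stays the same.

Within the data shown here, no measured pair of compounds isolates a change of this kind, so any expectation here is uncertain. The starting point is compound 2 at 4700 nM. A moderate move towards higher numbers is expected, a 1.9-fold higher number from compound 2 to compound 4 (0.28 log units; within the scatter), and the assay may even report only a limit. For compound 4 the estimated value is 9000 nM, with an expected range from 2500 nM to 25000 nM.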

Compound 4, half-maximal effective concentration: 1100 nM
Estimate against measurement, compound 4: 8.2-fold (0.91 log units) above, outside the stated range (below it).
By their numbers in this assay, from the lowest: compound 4; then compounds 2 and 1 (each within the scatter of the next). At a limit, above all of these: compound 3.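

In this assay, within the data shown here, the swap of methyl for 2-(tert-butoxycarbonyl)ethyl, with the rest of the structure unchanged, gives a 4.3-fold lower number from compound 2 to compound 4 (0.63 log units; beyond the scatter) and is the first readable step at this place. Among these compounds, the earlier compounds offered no pair that isolated a change here, so this pair is the first sign that the group on the ring amine nitrogen can grow well beyond methyl without the effect being lost; in this pair, the effect even appears at smaller amounts of compound. Why the larger group lowers the number cannot be said, as nothing measured here bears on a reason.

A single step cannot separate the contribution of the added chain length from that of the tert-butoxycarbonyl group at its end. Whether a plain butyl chain, the free carboxylic acid or an amine at the end of the chain would give a similar step therefore remains an open question, as does whether a still longer chain would take the number lower or raise it again.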